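From Dimethylaminomethyl to Cyclopropylcarbamoyl on a Shared Core

The compounds below may be only part of what the source reports. "The series", "measured", "known", "first", "only" and "open" are said of these compounds alone.

Compound 2 `CN(C)CC[C@@H]1C[C@@H](c2ccc(Cl)c(Cl)c2)[C@H](NC(=O)c2cc(-c3c(Cl)cnn3C)c(Cl)o2)CN1` and compound 1 `Cn1ncc(Cl)c1-c1cc(C(=O)N[C@@H]2CN[C@H](CC(N)=O)C[C@H]2c2ccc(Cl)c(Cl)c2)oc1Cl` share one core and differ only in the group on a saturated chain carbon bound to a saturated ring carbon. In an assay for inhibition of RAC-alpha serine/threonine-protein kinase (Homo sapiens), read by HTRF, with a stated time of 1 h (on this read-out higher numbers stand for weaker inhibition and lower numbers for stronger inhibition), compound 1 gives 3.24 nM, and compound 2 gives 3.4 nM. The step of a 1.0-fold higher number from compound 1 to compound 2 (0.02 log units; within the scatter) shows that carbamoyl and (dimethylamino)methyl at this place give numbers within the scatter of each other. On the numbers shown, compound 2 thus stands level with compound 1, with no order to be read between them.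

Compound 3 `Cn1ncc(Cl)c1-c1cc(C(=O)N[C@@H]2CN[C@H](CC(=O)NC3CC3)C[C@H]2c2ccc(Cl)c(Cl)c2)oc1Cl` has not yet been measured. It differs from compound 2 in one place: cyclopropylcarbamoyl in place of (dimethylamino)methyl on a saturated chain carbon bound to a saturated ring carbon. Going by the values given here, the only measured step that bears on this place is a 1.0-fold higher number from compound 1 to compound 2 (0.02 log units; within the scatter), which was within the scatter; it is the single guide available, and compound 3 brings back an amide at this place as in compound 1. Because a 1.0-fold higher number from compound 1 to compound 2 (0.02 log units; within the scatter) showed this place tolerating a swap, compound 3 is expected to show a step of a 1.2-fold higher number from compound 2 to compound 3 (0.07 log units; within the scatter), none beyond the scatter. Compound 3 is therefore estimated at 4 nM, with a range from 1.5 nM to 12 nM.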

Compound 3, half-maximal inhibitory concentration: 3.95 nM
Compound 3: middle estimate off by 1.0-fold (0.01 log units), on the high side, and the stated range covers the measured number.
By their numbers in this assay, from the lowest: compounds 1, 2 and 3 (each within the scatter of the next).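

In this assay the exchange of (dimethylamino)methyl for cyclopropylcarbamoyl gives a 1.2-fold higher number from compound 2 to compound 3 (0.07 log units; within the scatter) and so stays within the scatter, even though the entering group has 6 heavy atoms against 4 and carries a three-membered non-aromatic ring of carbon only. The earlier pair had compared only carbamoyl with (dimethylamino)methyl, whereas the new pair of amides tests a substituent on the amide nitrogen itself: cyclopropyl in place of hydrogen on an amide-type nitrogen gives a 1.2-fold higher number from compound 1 to compound 3 (0.09 log units; within the scatter) and likewise stays within the scatter, so on these compounds the amide hydrogen can give way to cyclopropyl with no step beyond the scatter. Nothing at hand gives a reason why these three groups on a saturated chain carbon bound to a saturated ring carbon read alike.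

The compounds shown leave open how far this tolerance extends, since all three numbers lie within the scatter of their neighbours and none marks a limit at this place. A carboxylic acid, a primary amine, a longer chain or a cyclohexyl group on the amide nitrogen could each still show a step beyond the scatter, or none.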